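Swapping a phenyl for a methyl on a bis-indole quinone

A few compounds are considered here, and "the series" means these few. Any claim that something is new, unique, unknown or untested is made for them only; others in the source may bear on it.

Of the compounds shown here, three built on a shared core have been tested in a functional assay on MCF7 cells (Homo sapiens) for antiproliferative activity, read by CCK-8 assay, with a stated time of 48 h; a lower number here means a stronger inhibitor, a higher number a weaker inhibitor. Compound 1 `COc1ccc2[nH]c(C)c(C3=C(Br)C(=O)C(c4c(-c5ccccc5)[nH]c5ccccc45)=C(Br)C3=O)c2c1` gives 2.57 ug/mL. Compound 2 `Cc1[nH]c2ccccc2c1C1=C(Br)C(=O)C(c2c(-c3ccccc3)[nH]c3ccccc23)=C(Br)C1=O` gives 3.02 ug/mL, and compound 3 `Cc1ccc(-c2[nH]c3ccccc3c2C2=C(Br)C(=O)C(c3c(C)[nH]c4ccccc34)=C(Br)C2=O)cc1` gives 3.25 ug/mL. Compound 1 shows the lowest of the three numbers, but its gaps to compound 2 and compound 3 lie within the scatter, so no order can be claimed. The two measured steps, a 1.2-fold higher number from compound 1 to compound 2 (0.07 log units; within the scatter) and a 1.1-fold higher number from compound 2 to compound 3 (0.03 log units; within the scatter), each concern a small change and each stays within the scatter. Compound 4 `COc1ccc2[nH]c(C)c(C3=C(Br)C(=O)C(c4c(C)[nH]c5ccccc45)=C(Br)C3=O)c2c1` differs from compound 1 by methyl in place of phenyl on an aromatic carbon. Among the measured compounds shown here, no measured step covers this change, so the expectation rests on the narrow spread seen across compound 1, compound 2 and compound 3. Compound 4 is therefore expected to give 3.2 ug/mL, within 1.5 ug/mL to 7 ug/mL, meaning an estimated step of a 1.2-fold higher number from compound 1 to compound 4 (0.10 log units; within the scatter).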

Compound 4, half-maximal inhibitory concentration: > 25 ug/mL
Compound 4: only a limit was reported; the forecaster's own chance of this, stated with the estimate: 3%; at least 7.8-fold (0.89 log units) between middle value and limit.
By their numbers in this assay, from the lowest: compounds 1, 2 and 3 (each within the scatter of the next). At a limit, above all of these: compound 4.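

In this assay, among the compounds shown here, this is the first change on the shared core that moves the number beyond the scatter: methyl in place of phenyl, on the carbon next to the ring nitrogen, gives an at least 9.7-fold higher number from compound 1 to compound 4 (0.98 log units; beyond the scatter). The value for compound 4 is a limit, not a number: the limit of > 25 ug/mL in this assay, at which 1 of the 4 values shown sits.

So the true size of the step stays unknown, and only its lower bound can be read. From the compounds shown here alone, what a longer chain such as butyl, a cyclohexyl ring or a pyridine ring would do at this place also stays open.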